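This account rests on a few compounds, and the source may have more. Where it says the series, first, only, none or still open, it means among the compounds named here.

Compound 1 `N#Cc1c(N)nc(SCc2cccnc2)c(C#N)c1-c1ccc(OCC2CC2)cc1` is the starting point. In an assay on CHO cells for displacement of a labelled ligand from adenosine receptor A1 (Homo sapiens), read by scintillation counting, with a stated time of 90 min (on this read-out lower numbers stand for stronger inhibition and higher numbers for weaker inhibition), compound 1 gives 67 nM, the lowest of the three numbers at hand. Compound 2 `C=CCOc1ccc(-c2c(C#N)c(N)nc(SCC(N)=O)c2C#N)cc1` gives 323 nM in this assay, and compound 3 `CC(C)COc1ccc(-c2c(C#N)c(N)nc(SCC(N)=O)c2C#N)cc1` gives 603 nM; both differ from compound 1 in two places at once, at the chain on the aromatic oxygen and at the group on the sulfur, so their gap to compound 1 cannot be tied to either change on its own. Within the data shown here, the only single-point step among the measured compounds, a 1.9-fold higher number from compound 2 to compound 3 (0.27 log units; within the scatter), concerns the chain on the aromatic oxygen alone and lies within the scatter. Compound 4 `COC(=O)c1cccc(CSc2nc(N)c(C#N)c(-c3ccc(OCC4CC4)cc3)c2C#N)c1` has not yet been measured. It differs from compound 1 by 3-(methoxycarbonyl)phenyl in place of pyridin-3-yl on a saturated chain carbon bound to a sulfur. Among the measured compounds shown here, no measured step changes the group on the sulfur by itself, so the expectation for compound 4 rests on compound 1 holding the lowest number and on the absence of any large single-point shift among the measured compounds. For compound 4 a step of about a 1.8-fold higher number from compound 1 to compound 4 (0.25 log units; within the scatter) is expected in this assay, a small move toward a higher number that stays near the scatter. The estimated value for compound 4 in this assay is 120 nM, with a range from 30 nM to 500 nM.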

Compound 4, inhibition constant: 66 nM
Compound 4: the middle estimate sits 1.8-fold (0.26 log units) above what was measured, within the range that was stated.
By their numbers in this assay, from the lowest: compounds 4 and 1 (each within the scatter of the next); then compounds 2 and 3 (each within the scatter of the next).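

In this assay, among these compounds, the step of a 1.0-fold lower number from compound 1 to compound 4 (0.01 log units; within the scatter) is the first measured change made only at the group on the sulfur, which the earlier compounds could not isolate. It replaces (pyridin-3-yl)methyl with 3-(methoxycarbonyl)benzyl, so a group of 10 heavy atoms with a ring of carbon only enters where a group of 6 heavy atoms with a ring nitrogen leaves, yet the two compounds cannot be told apart on this read-out; for this one pair, then, neither the ring nitrogen nor the added methoxycarbonyl group shifts the number beyond the scatter. No supporting measurement is available to explain why these two groups give such a similar result.

The compounds shown leave open whether this holds for other groups on the ring, such as a carboxylic acid or an amine in place of the methoxycarbonyl group, or an unsubstituted benzyl group on the sulfur. They also leave open how much of the gap to compound 2 and compound 3 belongs to the amide-bearing group on the sulfur, since those compounds also differ in the chain on the aromatic oxygen.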